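Azepanyl replacing butyl(methyl)amino in a sulfonamide amide series

This account rests on a few compounds, and the source may have more. Where it says the series, first, only, none or still open, it means among the compounds named here.

Measured compounds:
compound 1 `CC(C(=O)NCc1ccc(C(F)(F)F)nc1NC1CCCCC1)c1ccc(NS(C)(=O)=O)c(F)c1`, 260 nM
compound 2 `CCCCN(C)c1nc(C(F)(F)F)ccc1CNC(=O)C(C)c1ccc(NS(C)(=O)=O)c(F)c1`, 21.3 nM
compound 3 `CC(C(=O)NCc1ccc(C(F)(F)F)nc1N1CCC(C(=O)c2ccc(F)cc2)CC1)c1ccc(NS(C)(=O)=O)c(F)c1`, 990 nM

In a functional assay on CHO-K1 cells for antagonist activity at transient receptor potential cation channel subfamily V member 1 (Homo sapiens), read by FLIPR (a lower number here means a stronger inhibitor, a higher number a weaker inhibitor), compound 2 gives the lowest number of the three. For the measured compounds named here, the only single-point step recorded, a 12-fold lower number from compound 1 to compound 2 (1.09 log units; beyond the scatter), is large. Compound 3, which carries a substituted piperidinyl group at the same place, gives 990 nM, the highest number of the set.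

Compound 4 `CC(C(=O)NCc1ccc(C(F)(F)F)nc1N1CCCCCC1)c1ccc(NS(C)(=O)=O)c(F)c1` differs from compound 2 in one place: azepan-1-yl in place of butyl(methyl)amino on an aromatic carbon. Going by the values given here, no measured step describes this exact exchange. The step from compound 1 to compound 2 shows that the group at this aromatic carbon moves the number strongly, and compound 3 shows that a larger ring-bearing group at the same place gives a much higher number than compound 2. Azepan-1-yl keeps the tertiary nitrogen of compound 2 but closes it into a seven-membered ring, so a modest rise relative to compound 2 is expected rather than a change of the size seen for compound 3; the expected step is a 2.8-fold higher number from compound 2 to compound 4 (0.45 log units; beyond the scatter). Compound 4 is therefore estimated at 60 nM, with a range from 15 nM to 250 nM.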

Compound 4, half-maximal inhibitory concentration: 25.1 nM
Compound 4: the middle estimate sits 2.4-fold (0.38 log units) above what was measured; measured number inside the range.
By their numbers in this assay, from the lowest: compounds 2 and 4 (each within the scatter of the next); then compound 1; then compound 3.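

In this assay, a 1.2-fold higher number from compound 2 to compound 4 (0.07 log units; within the scatter) shows that this position, next to the ring nitrogen, accepts azepan-1-yl and butyl(methyl)amino alike: the open chain and the seven-membered ring cannot be told apart here. The large step of a 10-fold lower number from compound 1 to compound 4 (1.02 log units; beyond the scatter) shows that the gain over cyclohexylamino is not confined to the open chain seen in compound 2. A ring on this nitrogen does not by itself secure a low number, as compound 3, with its substituted piperidinyl group, gives 990 nM in this assay.

On these data alone, whether unsubstituted piperidin-1-yl, pyrrolidin-1-yl or an azepane carrying a hydroxyl group would stay with compound 2 and compound 4 remains open. Nothing at hand explains why these groups give the numbers they do.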